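One more methyl on the chain of compound 3

The source may hold more compounds than are shown below. What is called first, only, known or untested is meant among the compounds shown, and "the series" means these compounds.

In a functional assay on A549 cells (Homo sapiens) for antiproliferative activity, read by MTT assay, with a stated time of 72 h (on this read-out lower numbers stand for stronger inhibition and higher numbers for weaker inhibition), compound 3 (`CC/C=C/C(=O)Nc1cccc(Oc2nc(Nc3ccc(OC)cc3)nc3c2CSCC3)c1`) gives 20100 nM. Compound 2 (`C/C=C/C(=O)Nc1cccc(Oc2nc(Nc3ccc(OC)cc3)nc3c2CSCC3)c1`) gives 22200 nM and compound 1 (`CC(C)/C=C/C(=O)Nc1cccc(Oc2nc(Nc3cccc(C#N)c3)nc3c2CSCC3)c1`) gives 35900 nM. All three numbers lie within the scatter of one another, so compound 3 does not stand apart from the other two.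

Compound 4 (`COc1ccc(Nc2nc3c(c(Oc4cccc(NC(=O)/C=C/C(C)C)c4)n2)CSCC3)cc1`) differs from compound 3 in one place: methyl in place of hydrogen on a saturated chain carbon bound to a double-bonded chain carbon and a saturated chain carbon. The ethyl becomes isopropyl, and the but-1-en-1-yl becomes 3-methylbut-1-en-1-yl.

Among the measured compounds shown here, one measured step bears directly on this change, a methyl in place of hydrogen on a saturated chain carbon bound to a double-bonded chain carbon: a 1.1-fold lower number from compound 2 to compound 3 (0.04 log units; within the scatter). That step stays within the scatter. Compound 1 also carries the 3-methylbut-1-en-1-yl group, though it differs elsewhere too, and its 35900 nM lies within the scatter of the other two values.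

No shift beyond the scatter is therefore expected in this assay, in either direction. The expected step is a 1.1-fold higher number from compound 3 to compound 4 (0.06 log units; within the scatter). For compound 4 the estimate is 23000 nM, with an expected range from 12000 nM to 42000 nM.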

Compound 4, half-maximal inhibitory concentration: 25900 nM
Compound 4: the middle estimate sits 1.1-fold (0.05 log units) below what was measured, and the stated range covers the measured number.
By their numbers in this assay, from the lowest: compounds 3, 2, 4 and 1 (each within the scatter of the next).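

In this assay the added methyl on this saturated chain carbon gives a 1.3-fold higher number from compound 3 to compound 4 (0.11 log units; within the scatter) and so does not separate isopropyl from ethyl at the chain end. Isopropyl in place of methyl on the double-bonded chain carbon gives a 1.2-fold higher number from compound 2 to compound 4 (0.07 log units; within the scatter) and shows that the wider change from methyl to isopropyl also leaves the number within the scatter, while 4-methoxyphenyl in place of 3-cyanophenyl on the nitrogen gives a 1.4-fold lower number from compound 1 to compound 4 (0.14 log units; within the scatter) with the 3-methylbut-1-en-1-yl group held fixed. No supporting evidence bears on these values.

Open, on these data alone, is whether a dimethylamino group or a carboxylic acid at the chain end would move the number beyond the scatter. As far as these compounds go, a longer chain such as hexenyl at this position also remains open.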